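A cyclohexyl group replaces a 2-(2-methoxyethoxy)ethyl chain

The source may report more compounds than this note shows. Statements on the series, on what has been measured and on what is new or still open speak of the compounds shown alone.

Measured in a functional assay on RAW264.7 cells (Mus musculus) for inhibition, read by ELISA, with a stated time of 24 h; on this read-out higher numbers stand for an effect only at larger amounts of compound and lower numbers for an effect already at smaller amounts:
compound 1 `CC/C=C\C[C@H]1C(=O)C=C[C@H]1CC(=O)OCCCC`: 23000 nM
compound 2 `CC/C=C\C[C@H]1C(=O)C=C[C@H]1CC(=O)OCCOCCOC`: 33000 nM

Among the measured compounds shown here, compound 2, at 33000 nM, stands within the scatter of compound 1, the only other measured compound. Compound 3 `CC/C=C\C[C@H]1C(=O)C=C[C@H]1CC(=O)OC1CCCCC1` differs from compound 2 at one place: cyclohexyl in place of 2-(2-methoxyethoxy)ethyl on an oxygen next to a carbonyl group. For the measured compounds named here, the one measured step bearing on this change is a 1.4-fold higher number from compound 1 to compound 2 (0.16 log units; within the scatter), and it altered the same chain. Going by the values given here, no measured compound carries a ring at this place, so the evidence is thin. No step beyond the scatter is therefore expected in this assay. The estimated step is a 1.3-fold lower number from compound 2 to compound 3 (0.12 log units; within the scatter). For compound 3 the expected value is 25000 nM, with an estimated range of 10000 nM to 60000 nM.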

Compound 3, half-maximal effective concentration: 22000 nM
Beside the measured number, compound 3's estimate is 1.1-fold (0.06 log units) above it; low and high end bracket the measured number.
By their numbers in this assay, from the lowest: compounds 3, 1 and 2 (each within the scatter of the next).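

In this assay, the first ring at this place, on an oxygen next to a carbonyl group, leaves the number within the scatter of both open chains: the change from 2-(2-methoxyethoxy)ethyl to cyclohexyl gives a 1.5-fold lower number from compound 2 to compound 3 (0.18 log units; within the scatter), and the change from butyl to cyclohexyl gives a 1.0-fold lower number from compound 1 to compound 3 (0.02 log units; within the scatter). The three groups at this place thus include chains and a ring, with and without oxygen atoms, and none stands apart. No evidence is available to explain this. From the compounds shown here alone, whether an amine, a carboxylic acid or a phenyl ring at this place would give a step beyond the scatter remains open, as does the effect of any change elsewhere on the shared core.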